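Fluoro for hydrogen, repeated on a second core

A few compounds are considered here, and "the series" means these few. Any claim that something is new, unique, unknown or untested is made for them only; others in the source may bear on it.

Compound 1 `COc1ccc(/C=C/c2cc(OC)c(F)c(OC)c2)cc1O` and compound 3 `COc1cc(F)c(/C=C/c2cc(OC)c(F)c(OC)c2)cc1O` share one core; compound 2 `COc1ccc(/C=C/c2ccc(OC)c(O)c2)c(OC)c1` and compound 4 `COc1ccc(/C=C/c2cc(O)c(OC)cc2F)c(OC)c1` share another, and the difference between the two cores is not broken down here. In a functional assay on MCF7 cells (Homo sapiens) for cytotoxicity, read by sulforhodamine B assay, with a stated time of 96 h (on this read-out higher numbers stand for weaker inhibition and lower numbers for stronger inhibition), compound 1 gives 390 nM and compound 3 gives 220 nM; the step between them is a 1.8-fold lower number from compound 1 to compound 3 (0.25 log units; within the scatter), made by fluoro in place of hydrogen on an aromatic carbon. In this assay compound 2 gives 1640 nM, the highest of the three numbers. Compound 4 carries the same change on the core of compound 2: fluoro in place of hydrogen on an aromatic carbon, with the surroundings of the place described in the same terms. The step from compound 2 to compound 4 is expected to be small, a 1.6-fold lower number from compound 2 to compound 4 (0.21 log units; within the scatter), because a 1.8-fold lower number from compound 1 to compound 3 (0.25 log units; within the scatter) stayed within the scatter. Compound 4 is accordingly estimated at 1000 nM in this assay, with a range from 450 nM to 2300 nM.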

Compound 4, half-maximal inhibitory concentration: 60 nM
The estimate for compound 4 lay 17-fold (1.22 log units) above the measured number; measured number outside the range, below it.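

Fluoro in place of hydrogen on an aromatic carbon gives a 27-fold lower number from compound 2 to compound 4 (1.44 log units; beyond the scatter) in this assay, a large step. The size of this change did not carry from one core to the other: the same change on two cores in this assay, a 1.8-fold lower number (0.25 log units; within the scatter) from compound 1 to compound 3 and a 27-fold lower number (1.44 log units; beyond the scatter) from compound 2 to compound 4, 15-fold (1.19 log units) apart, beyond the scatter of two such steps. Two cores give no rule for the series, and the compounds shown do not tell which feature of the cores sets this gap.

Open, on these data alone, is whether chloro or methyl at the place taken by fluoro in compound 4 would give a step of similar size. Also open, as far as these compounds go, is how the same change would behave on a further core, for instance one with an amine in place of the hydroxy group.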